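The source may hold more compounds than are shown below. What is called first, only, known or untested is meant among the compounds shown, and "the series" means these compounds.

The measured compounds and their values:

compound 1, `CCC(C(=O)N1CCN(c2cccc(F)c2)CC1)N1C(=O)CCC1=O`: 0%
compound 2, `CC(C(=O)N1CCN(c2ccc(C(F)(F)F)cc2)CC1)N1C(=O)CCC1=O`: 0%
compound 3, `CC(C(=O)N1CCN(c2ccc(F)cc2)CC1)N1C(=O)CCC1=O`: 50%

All three were tested in a functional assay on the whole organism (strain Swiss) with Mus musculus as the target, in the maximal electroshock model, with a stated time of 2 h, at a dose of 300 mg/kg by the intraperitoneal route; a lower number here means a weaker effect, a higher number a stronger effect of the compound at the dose given. Compound 3 gives 50% in this assay and is the only one of the three with a read-out other than nil. Within the data shown here, the single change that turns compound 3 into compound 2 is trifluoromethyl in place of fluoro on an aromatic carbon, and it made a step of a number 50 percentage points lower from compound 3 to compound 2 (beyond the scatter). Compound 1 gives 0% in this assay, which is level with compound 2 at the digits printed, so no order or change can be read between the two. The difference between the core of compound 1 and the core of compound 3 is not broken down here.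

Compound 4, `CCC(C(=O)N1CCN(c2cccc(C(F)(F)F)c2)CC1)N1C(=O)CCC1=O`, has not yet been measured in this assay. It differs from compound 1 by trifluoromethyl in place of fluoro on an aromatic carbon. Among the measured compounds shown here, this is the same kind of change as the one from compound 3 to compound 2, though not the same: around the place, the group in compound 4 sits meta to a large group, whereas in compound 2 it sits para to a large group. On the measured pair, this kind of change lowered the read-out by a large step. Compound 1, however, already stands at the lowest read-out the assay can report, because its value is 0%, so no further drop can be seen from it. The step expected from compound 1 to compound 4 is therefore estimated as no change at the digits printed from compound 1 to compound 4 (within the scatter). Compound 4 is thus expected to give about 0% in this assay, with a range from 0% to 10%.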

Compound 4, a percentage reported as activity, at one dose (the size of the read-out at that dose, not a potency): 50%
For compound 4 the middle estimate is 50 percentage points below the measured one, outside the stated range (above it).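

In this assay, trifluoromethyl in place of fluoro on an aromatic carbon gives a number 50 percentage points higher from compound 1 to compound 4 (beyond the scatter), and set beside the earlier step the change does not carry over from one core to the other: the same change on two cores in this assay, a number 50 percentage points lower (beyond the scatter) from compound 3 to compound 2 and a number 50 percentage points higher (beyond the scatter) from compound 1 to compound 4, 100 percentage points apart, beyond the scatter of two such steps

The outcome of this exchange on one pair therefore cannot be transferred to the other pair in this series, and the two pairs shown give no single direction for it. What the result does not show is which difference between the pairs matters: in compound 4 the trifluoromethyl sits meta to a large group, the pair of compound 3 and compound 2 carries the change at another place on the ring, and the cores differ as well, so place and core cannot be told apart here and no reason for the reversal can be read.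

The compounds shown leave open how a chloro, a methoxy or a nitrile on the same aromatic carbon would behave on either core. They also leave open whether fluoro and trifluoromethyl at the other place on each core would separate the part played by the place from that played by the core.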